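From 2-methylphenyl to 3-bromophenyl in the series

This account rests on a few compounds, and the source may have more. Where it says the series, first, only, none or still open, it means among the compounds named here.

Of the compounds shown here, two have been measured so far. In a functional assay on MCF7 cells (Homo sapiens) for cytotoxicity, read by MTT assay, with a stated time of 96 h (on this read-out lower numbers stand for stronger inhibition and higher numbers for weaker inhibition), compound 1 `COc1ccccc1-n1cc(C(=O)c2cc(OC)c(OC)c(OC)c2)c(-c2ccccc2)c1` gives 150 nM as its half-maximal inhibitory concentration. Compound 2 `COc1cc(C(=O)c2cn(-c3ccccc3)cc2-c2ccccc2C)cc(OC)c1OC` gives 190 nM on the same read-out, and these two values lie within the usual scatter of each other. For the measured compounds named here, they differ in more than one place, so the measurements offer no step for a single change.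

Compound 3 `COc1cc(C(=O)c2cn(-c3ccccc3)cc2-c2cccc(Br)c2)cc(OC)c1OC` has not yet been measured. It departs from compound 2 at one place: 3-bromophenyl in place of 2-methylphenyl on an aromatic carbon with 3-bromophenyl in place of 2-methylphenyl on an aromatic carbon of a five-membered aromatic ring with 1 nitrogen. Going by the values given here, no measured pair shows what this exchange does. Among the compounds with values here, the only guide is the level of compound 2 at 190 nM and of compound 1 at 150 nM in this assay so far. No change beyond the scatter is expected in this assay for this exchange, in either direction. The expected 1.3-fold lower number from compound 2 to compound 3 (0.10 log units; within the scatter) is therefore small. Compound 3 is estimated at 150 nM with an expected range from 40 nM to 500 nM on this read-out.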

Compound 3, half-maximal inhibitory concentration: 950 nM
The estimate for compound 3 lay 6.3-fold (0.80 log units) below the measured number, and the stated range ends below it.
By their numbers in this assay, from the lowest: compounds 1 and 2 (each within the scatter of the next); then compound 3.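

In this assay, for the compounds shown here, the exchange of 2-methylphenyl for 3-bromophenyl brings a 5.0-fold higher number from compound 2 to compound 3 (0.70 log units; beyond the scatter) and provides the first readable step. The aromatic carbon of the five-membered aromatic ring with 1 nitrogen, two ring bonds from the ring nitrogen, therefore responds to the group it carries, even though both groups have 7 heavy atoms, one six-membered aromatic ring of carbon only and no hydrogen-bond donors or acceptors. The two groups differ both in the substituent on the phenyl ring and in its numbered place, so this single step cannot be assigned to either difference alone.

Nothing in hand bears on the reason for the rise in the number. The open question is how 3-methylphenyl and 2-bromophenyl would read at this carbon, as they would separate the substituent from its place, and how a phenyl ring carrying an amine or a carboxylic acid would compare.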